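The compounds below may be only part of what the source reports. "The series", "measured", "known", "first", "only" and "open" are said of these compounds alone.

Measured so far:
compound 1 `Cc1c(N(C)C)nc(CCCCCCCCCCO)c(O)c1C` gives 20%
compound 2 `CCCCCCCCCCCCCCCCCCCc1c(C)c(N(C)C)nc(C)c1O` gives 8%

Both were tested in a functional assay on cells (Lymphocyte, Homo sapiens), read by trypan blue exclusion, with a stated time of 16 h, tested at 0.1 uM; on this read-out higher numbers stand for a stronger effect at the one concentration tested and lower numbers for a weaker effect. Within the data shown here, on these two numbers compound 1 stands highest; the only other compound, compound 2, sits lower, a gap beyond the usual scatter. From compound 1 the next step leads to compound 3 `CCCCCCCCCCCCCCCCc1nc(N(C)C)c(C)c(C)c1O`, not yet measured in this assay. The change is hexyl in place of hydroxy on a saturated chain carbon, ten or more bonds along the chain from an aromatic carbon. Among the measured compounds shown here, with no measured pair showing this exact change, its size can only be guessed. A drop from compound 1 seems more likely than a rise, because compound 2 without a hydroxy on its chain gives 8%, though the two compounds differ in more than that one place. The expected step is a number 8 percentage points lower from compound 1 to compound 3 (within the scatter), a modest fall that may not clear the scatter. For compound 3 the estimate in this assay is 12%, with a range from 3% to 25%.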

Compound 3, a percentage reported as activity, at one concentration (the size of the read-out at that concentration, not a potency): 29%
Compound 3: middle estimate off by 17 percentage points, on the low side; the measured number lies above the stated range.
By their numbers in this assay, from the lowest: compound 2; then compounds 1 and 3 (each within the scatter of the next).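

In this assay putting hexyl in place of hydroxy on a saturated chain carbon, ten or more bonds along the chain from an aromatic carbon, gives a number 9 percentage points higher from compound 1 to compound 3 (within the scatter) and so leaves the two compounds indistinguishable on this read-out. At this place, then, the chain can lose its hydroxy, with the hydrogen-bond donor and acceptor counted for it, and gain six carbons without a change that stands clear of the usual scatter. No independent measurement bears on why the read-out holds across this change.

Going by these compounds, whether an amine or a carboxylic acid at the same place would also leave the read-out unchanged remains open, as does the effect of a longer chain. A single concentration also leaves open whether the potencies of compound 1 and compound 3 match.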